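The source may hold more compounds than are shown below. What is called first, only, known or untested is meant among the compounds shown, and "the series" means these compounds.

Measured so far:
compound 1 `CCCCCCc1cc2cn(COCCO)c(O)nc-2n1` — > 400000 nM
compound 2 `C#Cc1cn(COCCO)c(=O)[nH]c1=O` — > 400000 nM

Of the compounds shown here, two have been tested in a functional assay on HEL cells (Homo sapiens), read by microscopy; on this read-out higher numbers stand for lower toxicity in this test and lower numbers for higher toxicity in this test. Compound 1 `CCCCCCc1cc2cn(COCCO)c(O)nc-2n1` carries a hexyl chain on its core; in this assay compound 1 gives > 400000 nM, which is a limit of the assay rather than a measured number. Compound 2 `C#Cc1cn(COCCO)c(=O)[nH]c1=O` belongs to a different core, and in this assay compound 2 also gives > 400000 nM, again a limit. Both values therefore sit at the limit of > 400000 nM in this assay, at which 2 of the 2 values shown sit, so neither compound showed any toxicity within the range that could be examined, and no ordering between them can be read from these figures.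

Compound 3 `CCCCCCCCCCCc1cc2cn(COCCO)c(O)nc-2n1` has not yet been tested. It differs from compound 1 by pentyl in place of hydrogen on a saturated chain carbon, six bonds along the chain from an aromatic carbon, so the hexyl chain of compound 1 becomes an undecyl chain. For the measured compounds named here, no measured pair of compounds shows what such a lengthening does here, since the only two values known are limits. The expectation is that compound 3 stays close to compound 1, a step of an at least 1.3-fold lower number from compound 1 to compound 3 (0.12 log units; that floor lies within the scatter) of small size or none beyond the scatter, with some chance that toxicity first appears at the longer chain. Compound 3 is estimated at 300000 nM, between 100000 nM and 400000 nM.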

Compound 3, minimum cytotoxic concentration: 80000 nM
Compound 3: middle estimate off by 3.8-fold (0.57 log units), on the high side; the whole stated range lies above it.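

Replacing the hexyl chain of compound 1 with the undecyl chain of compound 3 gives the first toxicity in this set that can be read as a number in this assay, a change that amounts to pentyl in place of hydrogen on a saturated chain carbon, six bonds along the chain from an aromatic carbon: an at least 5.0-fold lower number from compound 1 to compound 3 (0.69 log units; beyond the scatter). For the compounds shown here, this shows that the read-out responds to chain length on this shared core, which the earlier compounds could not show, since neither of them gave a value below the limit. The true size of the step may be larger than the printed floor, because the value for compound 1 is a limit and not a number: the limit of > 400000 nM in this assay, at which 2 of the 3 values shown sit.

From the compounds shown here alone, with only these two chain lengths on this core, it remains open where between hexyl and undecyl the toxicity first appears, and whether an octyl chain would already show it. Going by these compounds, it is also open whether a still longer chain would lower the number further, and whether an undecyl chain ending in an amine or a carboxylic acid would behave like the plain chain of compound 3.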